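Replacing (4-chlorophenyl)amino with 4-chlorophenyl

A few compounds are considered here, and "the series" means these few. Any claim that something is new, unique, unknown or untested is made for them only; others in the source may bear on it.

Compound 1 `C=C[C@@](C)(/C=C/c1ccc(OCc2ccccc2)cc1)CCC=C(C)C`: > 26000 nM
Compound 2 `C=C[C@@](C)(/C=C/c1ccc(Nc2ccc(Cl)cc2)cc1)CCC=C(C)C`: > 26000 nM

In a functional assay on Raji cells (Homo sapiens) for cytotoxicity, with a stated time of 72 h (a higher number here means that more compound is needed for the effect, a lower number that less compound is needed), compound 1 returns > 26000 nM, which is a limit and not a number. Compound 2 likewise returns only a limit, > 26000 nM. Both compounds therefore stand at the limit of > 26000 nM in this assay, at which 2 of the 2 values shown sit. For the measured compounds named here, the only measured step is a step that the two limits leave unreadable from compound 1 to compound 2, so it gives no size or direction for any further change.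

Compound 3 `C=C[C@@](C)(/C=C/c1ccc(-c2ccc(Cl)cc2)cc1)CCC=C(C)C` carries 4-chlorophenyl in place of (4-chlorophenyl)amino on an aromatic carbon, para to a large group: 4-chlorophenyl in place of (4-chlorophenyl)amino on an aromatic carbon. With no readable step to draw on, no change beyond the scatter is expected, and compound 3 is expected to remain near the same limit. The expected step is a step that the limit leaves unreadable from compound 2 to compound 3. Compound 3 is estimated at 30000 nM. Its expected range runs from 13000 nM to 70000 nM.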

Compound 3, half-maximal effective concentration: > 26000 nM
Compound 3 gave a limit, no number; the forecaster's own chance of this, stated with the estimate: 80%; the middle value lies beyond the limit too.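

For the compounds shown here, no step between compound 1, compound 2 and compound 3 can be read in this assay, since each result is a limit and not a number: the limit of > 26000 nM in this assay, at which 3 of the 3 values shown sit. The compounds shown leave open how these three differ and whether any group at this place gives a numerical value in this assay.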